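A Bromohydroxyphenyl Chalcone in Place of a Methoxypyridine

This account rests on a few compounds, and the source may have more. Where it says the series, first, only, none or still open, it means among the compounds named here.

Two chalcones built on one shared core have been examined for antiproliferative activity in a functional assay on SK-OV-3 cells (Homo sapiens) for antiproliferative activity, read by MTT assay, with a stated time of 24 h; a higher number here means a weaker inhibitor, a lower number a stronger inhibitor. Compound 1 `COc1ccc(C(=O)/C=C/c2ccc(N3CCCC3)cc2)c2c1C=CC(C)(C)O2` gives a full number: in this assay compound 1 gives 7370 nM. Compound 2 `COc1ccc(/C=C/C(=O)c2ccc(OC)c3c2OC(C)(C)C=C3)cn1` does not. For compound 2 in this assay only a limit is known, > 10000 nM. Compound 2 thus stands at the limit of > 10000 nM in this assay, at which 1 of the 2 values shown sits, so no number of its own can be set beside the value of compound 1. Compound 3 `COc1ccc(C(=O)/C=C/c2ccc(O)c(Br)c2)c2c1C=CC(C)(C)O2` differs from compound 2 in one place: 3-bromo-4-hydroxyphenyl in place of 6-methoxypyridin-3-yl on a double-bonded chain carbon bound to a double-bonded chain carbon. Because compound 2 rests at the limit of > 10000 nM in this assay, at which 1 of the 2 values shown sits, any number recorded for compound 3 in this assay would already mean a gain, and a modest improvement is expected, an at least 1.6-fold lower number from compound 2 to compound 3 (0.22 log units; that floor lies within the scatter). Compound 3 is estimated to give 6000 nM in this assay, with a likely span from 2000 nM to 20000 nM.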

Compound 3, half-maximal inhibitory concentration: > 10000 nM
Compound 3: only a limit was reported; the forecaster's own chance of this, stated with the estimate: 35%; at least 1.6-fold (0.22 log units) between middle value and limit.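

Among these compounds, no step from compound 2 to compound 3 can be read, because both compounds rest at a limit and neither has a number of its own: the limit of > 10000 nM in this assay, at which 2 of the 3 values shown sit.

The compounds shown leave open how far 3-bromo-4-hydroxyphenyl in place of 6-methoxypyridin-3-yl shifts the result in this assay.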